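The source may hold more compounds than are shown below. What is called first, only, known or untested is meant among the compounds shown, and "the series" means these compounds.

Measured so far:
Compound 1 `C[C@H](NC(=O)Nc1ccc(C(F)(F)F)cc1)c1ccccc1` gives 94% in an ADME assay on the whole organism with Oryza sativa as the target, tested at 1 uM; a higher number here means a weaker effect of the compound at the concentration tested, a lower number a stronger effect.
Compound 2 `C[C@H](NC(=O)Nc1ccc(F)cc1)c1ccccc1` gives 97% in this assay.
Compound 3 `C[C@@H](NC(=O)Nc1cccc(F)c1F)c1ccccc1` gives 99% in this assay.

Compound 4 `C[C@@H](NC(=O)Nc1cccc(C(F)(F)F)c1F)c1ccccc1` has not yet been measured. It differs from compound 3 by trifluoromethyl in place of fluoro on an aromatic carbon. The same kind of change was already made once among the measured compounds, from compound 2 to compound 1 (trifluoromethyl in place of fluoro on an aromatic carbon), where it gave a number 3 percentage points lower from compound 2 to compound 1 (within the scatter). The surroundings of the place differ, though: in compound 1 the entering group stands para to a large group, whereas in compound 4 it stands ortho to a fluoro group and meta to a large group, so this is the same kind of change, not the same change. How the cores of compound 2 and compound 3 differ is not broken down here.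

On that single earlier step, which lay within the scatter, a step of a number 3 percentage points lower from compound 3 to compound 4 (within the scatter) is expected from compound 3 to compound 4. For compound 4 the estimate is 96%, expected to fall between 86% and 100%.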

Compound 4, a percentage reported as activity, at one concentration (the size of the read-out at that concentration, not a potency): 99%
For compound 4 the middle estimate is 3 percentage points below the measured one; the range from low to high includes it.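

In this assay, putting trifluoromethyl in place of fluoro on an aromatic carbon gives no change at the digits printed from compound 3 to compound 4 (within the scatter). Set beside the earlier use of the same kind of change, the two cores show no difference that can be told apart: the same change on two cores in this assay, a number 3 percentage points lower (within the scatter) from compound 2 to compound 1 and no change at the digits printed (within the scatter) from compound 3 to compound 4, 3 percentage points apart, within the scatter of two such steps Neither step stands clear of the scatter, so this pair gives no measurable effect to carry from one core to another, and it does not show that the change would behave alike on other cores or at other positions.

The compounds shown carry only fluoro and trifluoromethyl groups on this aromatic ring. On these data alone, whether another group there, such as an amine or a carboxylic acid, would move the number beyond the scatter remains open.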